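The source may hold more compounds than are shown below. What is called first, only, known or untested is meant among the compounds shown, and "the series" means these compounds.

Working notes on the series:

- Compound 1 `O=C(Nc1ccc([N+](=O)[O-])cc1Cl)c1cccc2cc[nH]c12`: 1760 10^-6 cm/s
- Compound 2 `COc1cc([N+](=O)[O-])ccc1NC(=O)c1cc(Cl)ccc1O`: 334 10^-6 cm/s
- Compound 3 `O=C(Nc1c(Cl)cccc1Cl)c1cc(Cl)ccc1O`: 73 10^-6 cm/s
- Compound 4 `N#Cc1ccc(NC(=O)c2cccc3cc[nH]c23)c(Cl)c1`: not yet measured

In an ADME assay for permeability, using PAMPA (on this read-out lower numbers stand for lower permeability and higher numbers for higher permeability), compound 1 stands highest of the three measured compounds, and its gaps to compound 2 and compound 3 both lie beyond the scatter. Compound 4 keeps the core of compound 1 and has cyano in place of nitro on an aromatic carbon, meta to a chloro group and para to a large group: cyano in place of nitro on an aromatic carbon. Going by the values given here, no measured pair isolates a single change, so the only anchor is compound 1 at 1760 10^-6 cm/s. In this assay the expected change is none beyond the scatter, with an estimated 1.3-fold lower number from compound 1 to compound 4 (0.10 log units; within the scatter). The expected value for compound 4 is 1400 10^-6 cm/s, within an estimated range of 600 10^-6 cm/s to 3000 10^-6 cm/s.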

Compound 4, apparent permeability in the ADME assay: 553 10^-6 cm/s
Compound 4: the middle estimate sits 2.5-fold (0.40 log units) above what was measured, and the stated range ends above it.
By their numbers in the ADME assay, from the lowest: compound 3; then compounds 2 and 4 (each within the scatter of the next); then compound 1.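

Cyano in place of nitro on an aromatic carbon, meta to a chloro group and para to a large group, gives the first pair in the series that differs in one place, and the ADME assay shows a 3.2-fold lower number from compound 1 to compound 4 (0.50 log units; beyond the scatter). The number at this position therefore moves beyond the scatter with this exchange, while the core of compound 1 stays the same. In a physicochemical assay for solubility (on this read-out higher numbers stand for higher solubility and lower numbers for lower solubility), compound 1 gives < 1 ug/mL as a limit of the assay, not a number. In the physicochemical assay compound 4 gives < 1 ug/mL as a limit of the assay, not a number. In the physicochemical assay the step for this pair cannot be read: the limit of < 1 ug/mL in the physicochemical assay, at which 2 of the 2 values shown sit.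

On these data alone, how an amine or a carboxylic acid at this position would read remains open. So does whether the same exchange gives a similar step on another core.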